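Capping or removing the ring amine hydrogen in a camphor-like ester series

This account rests on a few compounds, and the source may have more. Where it says the series, first, only, none or still open, it means among the compounds named here.

Among the compounds with values here, the three compounds measured so far share one core, a bicyclic alcohol joined through an ester to a short chain that ends in a ring amine. Compound 1 `CC1(C)[C@H]2CC[C@]1(C)[C@H](OC(=O)CCN1CCNCC1)C2` carries a free amine hydrogen on that ring; in an ADME assay on MDCK cells (Canis lupus familiaris) for cytotoxicity, read by MTT assay, with a stated time of 48 h (on this read-out higher numbers stand for lower toxicity in this test and lower numbers for higher toxicity in this test), compound 1 gives 12600 nM, the lowest number of the three and thus the most toxic here. Compound 2 `CCOC(=O)N1CCN(CCC(=O)O[C@@H]2C[C@@H]3CC[C@@]2(C)C3(C)C)CC1` gives 150000 nM, and compound 3 `CCN1CCN(CCC(=O)O[C@@H]2C[C@@H]3CC[C@@]2(C)C3(C)C)CC1` gives 105000 nM. Both steps away from compound 1 raise the number: a 12-fold higher number from compound 1 to compound 2 (1.08 log units; beyond the scatter) and an 8.3-fold higher number from compound 1 to compound 3 (0.92 log units; beyond the scatter), while a 1.4-fold lower number from compound 2 to compound 3 (0.15 log units; within the scatter) shows that the two capped compounds sit together.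

Compound 4 `CC1CCN(CC(=O)O[C@@H]2C[C@@H]3CC[C@@]2(C)C3(C)C)CC1` has not yet been measured. It differs from compound 1 by 4-methylpiperidin-1-yl in place of (piperazin-1-yl)methyl on a saturated chain carbon bound to a carbonyl carbon. Like the two measured steps, this change removes the hydrogen-bond donor of the ring amine, though it also replaces one ring nitrogen with carbon and shortens the chain by one link. The two measured steps therefore bear on it only in part, but both point the same way and both lie beyond the scatter. A rise of similar size is expected, a 6.3-fold higher number from compound 1 to compound 4 (0.80 log units; beyond the scatter), so compound 4 is estimated at 80000 nM, with a likely range from 25000 nM to 200000 nM.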

Compound 4, half-maximal cytotoxic concentration: 93900 nM
For compound 4 the middle estimate is 1.2-fold (0.07 log units) below the measured one, and the stated range covers the measured number.
By their numbers in this assay, from the lowest: compound 1; then compounds 4, 3 and 2 (each within the scatter of the next).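

In this assay, the step to compound 4 is a 7.5-fold higher number from compound 1 to compound 4 (0.87 log units; beyond the scatter), so a higher number than that of compound 1 is reached even when the whole (piperazin-1-yl)methyl group gives way to 4-methylpiperidin-1-yl. In compounds 2 and 3 the ring kept both of its nitrogens and only the amine hydrogen was replaced, whereas compound 4 shows that the higher number does not require the second ring nitrogen or the longer chain of compound 1, and the entering group has the same count of 7 heavy atoms as the one it replaces. No measurement here explains why this change is linked to lower toxicity in this test.

On these data alone, three things change at once in this step: the amine hydrogen goes, a ring nitrogen becomes carbon, and the chain is shorter, so the share of each in the rise stays open. A piperazin-1-yl group on the shorter chain or a morpholine ring on either chain would help to pull these apart, while a free amine on a piperidine ring would test whether the amine hydrogen alone tracks with the low number of compound 1.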